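Shifting the Carboxyl and Methylating the Amine Nitrogen

The source may report more compounds than this note shows. Statements on the series, on what has been measured and on what is new or still open speak of the compounds shown alone.

Of the compounds shown here, three that share one core have been measured in an assay on isolated protein for agonist activity at Bile acid receptor (Homo sapiens), read by FRET; a lower number here means a smaller maximal response, a higher number a larger maximal response. Compound 1 `CC(C)c1onc(-c2c(Cl)cccc2Cl)c1COc1ccc(N(C)C(=O)c2ccc(C(=O)O)cc2)c(C(F)(F)F)n1` gives 101% in this assay, and compound 2 `CC(C)c1onc(-c2c(Cl)cccc2Cl)c1COc1ccc(N(C)C(=O)c2cccc(C(=O)O)c2)c(C(F)(F)F)n1` gives 110%. Compound 3 `CC(C)c1onc(-c2c(Cl)cccc2Cl)c1COc1ccc(NCc2ccc(C(=O)O)cc2)c(C(F)(F)F)n1` gives 97%, the lowest of the three numbers; the gap to compound 1 lies within the scatter, while the gap to compound 2 lies beyond it.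

Compound 4 `CC(C)c1onc(-c2c(Cl)cccc2Cl)c1COc1ccc(N(C)Cc2cccc(C(=O)O)c2)c(C(F)(F)F)n1` has not yet been measured. It differs from compound 3 in one place: (3-carboxybenzyl)(methyl)amino in place of (4-carboxybenzyl)amino on an aromatic carbon. The change has two parts. One part, a 3-carboxyphenyl in place of a 4-carboxyphenyl, has a measured counterpart in a number 9 percentage points higher from compound 1 to compound 2 (within the scatter), a step within the scatter. The other part, the methyl on the nitrogen, appears in compound 1 and compound 2 but never as a single step from an unmethylated partner, so its own effect is not known from these data.

Within the data shown here, with the one measured step being small, compound 4 is expected to show a step of a number 7 percentage points higher from compound 3 to compound 4 (within the scatter), upward but not beyond the scatter. The estimate for compound 4 is 104%, with a range from 90% to 118%.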

Compound 4, largest response reached (reported as efficacy), in percent of the reference or control that the assay uses: 102%
Compound 4: the middle estimate sits 2 percentage points above what was measured; the measured number falls inside the stated range.
By their numbers in this assay, from the lowest: compounds 3, 1, 4 and 2 (each within the scatter of the next, the first and the last beyond it).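

In this assay, among these compounds, replacing (3-carboxyphenyl)carbonyl with 3-carboxybenzyl on the nitrogen gives a number 8 percentage points lower from compound 2 to compound 4 (within the scatter), so this pair shows for the first time what happens when the carbonyl of the amide link is removed while the carboxyl stays in the same ring position. Larger changes at this position also leave the maximal response within the scatter: 3-carboxybenzyl in place of (4-carboxyphenyl)carbonyl gives a number 1 percentage points higher from compound 1 to compound 4 (within the scatter), and (3-carboxybenzyl)(methyl)amino in place of (4-carboxybenzyl)amino gives a number 5 percentage points higher from compound 3 to compound 4 (within the scatter), which places compound 4 within the scatter of each of the other three compounds. No measured evidence is available to explain why these steps stay small.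

The compounds shown still do not separate the methyl on the nitrogen from the shift of the carboxyl within the benzyl series, since that would take a partner of compound 4 with a hydrogen on the nitrogen, or a partner of compound 3 with a methyl there. From the compounds shown here alone, it also remains open whether the response would hold with an ethyl group on that nitrogen, a longer chain between the nitrogen and the benzene ring, or a primary amide in place of the carboxylic acid.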